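Hydroxy to phenyl on the aminophenyl amide head

The compounds below may be only part of what the source reports. "The series", "measured", "known", "first", "only" and "open" are said of these compounds alone.

Measured so far:
Compound 1 `Nc1ccccc1NC(=O)c1ccc(CNC2=N[C@@H](Cc3ccccc3)CS2)cc1` sits at the limit > 20000 nM in an assay on isolated protein for inhibition of protein deacetylase HDAC6 (Homo sapiens), read by fluorescence, with stated times of 3 h and 60 min; a lower number here means a stronger inhibitor, a higher number a weaker inhibitor.
Compound 2 `O=C(NO)c1ccc(CNc2nccc(-c3cccnc3)n2)cc1` gives 42 nM in this assay.
Compound 3 `Nc1cc(O)ccc1NC(=O)c1ccc(CNc2nccc(-c3cccnc3)n2)cc1` sits at the limit > 20000 nM in this assay.

Compound 3 stands at the limit of this assay, so only a bound and no number is known for it. The same holds for compound 1 (the limit of > 20000 nM in this assay, at which 2 of the 3 values shown sit). Among the compounds with values here, the single numbered value belongs to compound 2, and the one measured step, an at least 470-fold higher number from compound 2 to compound 3 (2.67 log units; beyond the scatter), is the swap of the amide head from hydroxy to the 2-amino-4-hydroxyphenyl group.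

The change now followed, (phenyl in place of hydroxy on an aromatic carbon), gives compound 4 `Nc1cc(-c2ccccc2)ccc1NC(=O)c1ccc(CNc2nccc(-c3cccnc3)n2)cc1`. It alters the head ring itself and leaves the tail untouched. Within the data shown here, no measured step touches a substituent on that ring; the only comparison with a step attached is the head swap, which was large and lost all measurable inhibition. Compound 1, with a different tail but an amino-phenyl head, also sits at the limit. The measurements therefore speak for the aminophenyl amide head as such, not for the hydroxy group on it.

Accordingly the step from compound 3 to compound 4 is expected to be a number no higher from compound 3 to compound 4 (the limit leaves the size open), none beyond the scatter, with a fair chance that again only a limit is reported. Compound 4 is estimated at 20000 nM, expected between 5000 nM and 60000 nM.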

Compound 4, half-maximal inhibitory concentration: > 20000 nM
Compound 4: no number, only a limit; the forecaster's own chance of this, stated with the estimate: 70%; the middle value lies on the limit itself.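

Compound 3 and compound 4 both give only a limit in this assay, so no step can be read for phenyl in place of hydroxy: the limit of > 20000 nM in this assay, at which 3 of the 4 values shown sit.

The compounds shown leave open whether hydroxy and phenyl on the aminophenyl amide head differ at all in inhibition, and whether any group there gives a measurable number.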